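A few compounds are considered here, and "the series" means these few. Any claim that something is new, unique, unknown or untested is made for them only; others in the source may bear on it.

The compounds here share one core and differ in the group attached to it and in its substituents, and all three measured ones were run in a physicochemical assay for lipophilicity; a higher number here means a more lipophilic compound, a lower number a more polar compound. Compound 1, `Cc1cc(Cl)c(-c2cn(C)cn2)cc1NC(=O)c1ccc(OCc2ccccn2)cc1`, gives 3.1 in this assay. Compound 2, `Cc1ccc(-c2c[nH]cn2)cc1NC(=O)c1ccc(OCc2ccccn2)cc1`, gives 2.8. For the measured compounds named here, compound 3, `Cc1cc(C)c(-c2nc3ccccc3[nH]2)cc1NC(=O)c1ccc(OCc2ccccn2)cc1`, is reported only as a limit of the assay, > 3.5, so no exact number is known for it; it is the one compound that sits at the limit of > 3.5 in this assay, at which 1 of the 3 values shown sits. Compound 3 therefore stands at or beyond the top of what is shown, with compounds 1 and 2 both below it by amounts that are beyond the scatter.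

The step from compound 3 leads to compound 4, `Cc1cc(C)c(-c2ccc(N)nn2)cc1NC(=O)c1ccc(OCc2ccccn2)cc1`. The change is 6-aminopyridazin-3-yl in place of 1H-benzimidazol-2-yl on an aromatic carbon, which in words means 6-aminopyridazin-3-yl in place of 1H-benzimidazol-2-yl on an aromatic carbon. Going by the values given here, no measured pair shows this change, so the expected step rests on the three values at hand. A clear step downward in this assay, well beyond the scatter, is expected, of size a number at least 1.00 log units lower from compound 3 to compound 4 (beyond the scatter). Compound 4 is therefore estimated at 2.5, within a range from 2 to 3.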

Compound 4, distribution coefficient: 2.6
The estimate for compound 4 lay 0.10 log units below the measured number; the range from low to high includes it.
By their numbers in this assay, from the lowest: compounds 4, 2 and 1 (each within the scatter of the next, the first and the last beyond it). At a limit, above all of these: compound 3.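

Placing 6-aminopyridazin-3-yl instead of 1H-benzimidazol-2-yl on this aromatic carbon, ortho to a methyl group and para to a methyl group, gives the first step that can be read in this assay: it is a number at least 0.90 log units lower from compound 3 to compound 4 (beyond the scatter). With the methyl groups left unchanged, this position now also has an exact reading, as compound 4 gives 2.6. The full size of the step stays open because compound 3 is reported only as a limit of the assay: the limit of > 3.5 in this assay, at which 1 of the 4 values shown sits.

The compounds shown do not separate the part played by the pyridazine ring from that of its amino group, which a plain pyridazin-3-yl at this carbon could address. On these data alone, how a carboxylic acid or a morpholine at the same carbon would read in this assay also remains open.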